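Tert-butyl in place of methyl on a shared core

The compounds below may be only part of what the source reports. "The series", "measured", "known", "first", "only" and "open" are said of these compounds alone.

Within the data shown here, compound 2 `Cc1ccc(Nc2ccc3c(c2)C(=O)N(C2CCC(=O)NC2=O)C3=O)cc1` gives 5% in an assay on FRT-Jurkat cells for inhibition of nuclear factor NF-kappa-B complex (Homo sapiens), read by flow cytometry, with a stated time of 24 h, tested at 10 uM (a lower number here means less inhibition, a higher number more inhibition at the concentration tested (going by the name of the read-out)), and stands second highest of the three numbers measured so far, though all three lie within the scatter of one another. Compound 1 `O=C1CCC(N2C(=O)c3cccc(Nc4ccccc4)c3C2=O)C(=O)N1` gives 4% and compound 3 `Cc1ccccc1Nc1cccc2c1C(=O)N(C1CCC(=O)NC1=O)C2=O` gives 7% in this assay so none of the three can be called stronger or weaker. Compound 4 `CC(C)(C)c1ccc(Nc2ccc3c(c2)C(=O)N(C2CCC(=O)NC2=O)C3=O)cc1` differs from compound 2 in one place, and tert-butyl in place of methyl on an aromatic carbon is that change. Among the measured compounds shown here, the only measured step that bears on it is a number 3 percentage points higher from compound 1 to compound 3 (within the scatter) which also put a small carbon group on a ring carbon and stayed within the scatter. The expected step of no change at the digits printed from compound 2 to compound 4 (within the scatter) is therefore one of no change beyond the scatter. For compound 4 the estimate is 5% with a range from -5% to 15% in this assay and the measurement will show what follows.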

Compound 4, a percentage reported as inhibition, at one concentration (the size of the read-out at that concentration, not a potency): 17%
Compound 4: middle estimate off by 12 percentage points, on the low side; the measured number lies above the stated range.
By their numbers in this assay, from the lowest: compounds 1, 2, 3 and 4 (each within the scatter of the next, the first and the last beyond it).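

Tert-butyl in place of methyl, para to a large group, gives the first step beyond the scatter in this assay, with a number 12 percentage points higher from compound 2 to compound 4 (beyond the scatter), though the step is modest. Among these compounds, earlier compounds showed no separation beyond the scatter between neighbours in one place, so this position is the first where a single change moves the read-out. No measurement here accounts for the rise. Still open, as far as these compounds go, is whether tert-butyl is special here, or whether an amine or a longer chain on this aromatic carbon would move the number as well.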